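The source may report more compounds than this note shows. Statements on the series, on what has been measured and on what is new or still open speak of the compounds shown alone.

In a functional assay with Homo sapiens as the target (a higher number here means a weaker inhibitor, a lower number a stronger inhibitor), three compounds sharing one core have been measured so far. Compound 1 `CC(C)[C@H](NC(=O)COc1cccc2ccccc12)C(=O)N[C@@H](CC(=O)O)C(=O)COC(=O)c1c(Cl)cccc1Cl` gives 11500 nM, compound 2 `CC(C)[C@H](NC(=O)COc1cccc2ccccc12)C(=O)N[C@@H](CC(=O)O)C(=O)COc1ccc(-c2ccccc2)cc1` gives 38700 nM, and compound 3 `CC(C)[C@H](NC(=O)COc1cccc2ccccc12)C(=O)N[C@@H](CC(=O)O)C(=O)COc1ccc(C(F)(F)F)cc1` gives 12300 nM. Two steps show where compound 3 stands: a 1.1-fold higher number from compound 1 to compound 3 (0.03 log units; within the scatter), and a 3.1-fold lower number from compound 2 to compound 3 (0.50 log units; beyond the scatter). It therefore sits level with compound 1 and clearly under compound 2.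

Compound 4 `CC(C)[C@H](NC(=O)COc1cccc2ccccc12)C(=O)N[C@@H](CC(=O)O)C(=O)COc1cc(F)ccc1F` has not yet been measured. It carries 2,5-difluorophenyl in place of 4-(trifluoromethyl)phenyl on an oxygen on a saturated carbon.

The three measured compounds differ only in the group at this same place, and even quite different groups there have moved the number only modestly. The largest change is a 3.4-fold higher number from compound 1 to compound 2 (0.53 log units; beyond the scatter). None of the three carries the incoming group, so this guide is only a rough one. No step beyond the scatter is therefore expected in this assay, in either direction. The expected step is a 1.0-fold lower number from compound 3 to compound 4 (0.01 log units; within the scatter). Compound 4 is estimated to give about 12000 nM, with an expected range of 5000 nM to 30000 nM.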

Compound 4, half-maximal inhibitory concentration: 19700 nM
The estimate for compound 4 lay 1.6-fold (0.22 log units) below the measured number; measured number inside the range.
By their numbers in this assay, from the lowest: compounds 1, 3, 4 and 2 (each within the scatter of the next, the first and the last beyond it).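

In this assay, 2,5-difluorophenyl on this oxygen cannot be told apart from any of the three earlier groups (as a 1.6-fold higher number from compound 3 to compound 4 (0.20 log units; within the scatter) and a 1.7-fold higher number from compound 1 to compound 4 (0.23 log units; within the scatter) and a 2.0-fold lower number from compound 2 to compound 4 (0.29 log units; within the scatter) show), so the new group falls inside the spread those groups already covered. For the compounds shown here, this is the first sign that a group with fluorine atoms directly on the aromatic ring and no trifluoromethyl, and with fewer heavy atoms than 4-(trifluoromethyl)phenyl, keeps the number in that same range, while only compound 1 and compound 2 remain separated by more than the scatter. No measurement here accounts for these numbers.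

The compounds shown leave open whether an amine or a carboxylic acid on this aromatic ring would move the number further. They also leave open what an unsubstituted phenyl would give at this place.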